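The compounds below may be only part of what the source reports. "The series", "measured", "known", "first", "only" and "open" are said of these compounds alone.

Of the compounds shown here, two of one shared core have been tested. In a functional assay on Ehrlich cells (Mus musculus) for cytotoxicity, read by trypan blue exclusion and cell counting, with a stated time of 2 h (on this read-out higher numbers stand for weaker inhibition and lower numbers for stronger inhibition), compound 1 `C/C(=N\N=C1\N=C(c2cc3ccccc3o2)CS1)c1nc(-c2ccccc2)[nH]c1C` gives 21.5 ug/mL, and in this assay compound 2 `CC1=N/C(=N/N=C(\C)c2nc(-c3ccccc3)[nH]c2C)S/C1=N\Nc1ccc(Cl)cc1` gives 20.3 ug/mL, the two numbers lying within the usual scatter of each other, so neither can be set apart. Compound 3 `CC1=N/C(=N/N=C(\C)c2nc(-c3ccccc3)[nH]c2C)S/C1=N\Nc1ccccc1` has not yet been measured. It differs from compound 2 by hydrogen in place of chloro on an aromatic carbon. Within the data shown here, with no comparable step among the measured pair, the expected change from compound 2 to compound 3, a 1.1-fold higher number from compound 2 to compound 3 (0.03 log units; within the scatter), is none beyond the scatter. Compound 3 is therefore estimated at 22 ug/mL, within 11 ug/mL to 44 ug/mL.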

Compound 3, half-maximal inhibitory concentration: 20.3 ug/mL
The estimate for compound 3 lay 1.1-fold (0.03 log units) above the measured number; low and high end bracket the measured number.
By their numbers in this assay, from the lowest: compounds 2, 3 and 1 (each within the scatter of the next).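

Among these compounds, this is the first comparison in the set that differs in only one place: going from 4-chlorophenyl to phenyl gives no change at the digits printed from compound 2 to compound 3 (within the scatter) in this assay and so the chloro is not needed to keep this level of cytotoxicity in this pair. Nothing measured here explains why the swap leaves the number in place. As far as these compounds go, whether an amine, a carboxylic acid or a longer chain at this place would shift the number remains open. So does whether the same swap would behave alike on a different core.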